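The source may hold more compounds than are shown below. What is called first, only, known or untested is meant among the compounds shown, and "the series" means these compounds.

Compound 1, `COC(=O)C[C@H](NC(=O)OC(C)(C)C)C(=O)N(Cc1ccccc1)C1(C(=O)NCc2ccccc2)CCN(Cc2ccccc2)CC1`, is the weakest of the three measured compounds in a functional assay on L1210 cells (Mus musculus) for inhibition, with a stated time of 48 h (a lower number here means a stronger inhibitor, a higher number a weaker inhibitor), where compound 1 gives 18000 nM. Compound 2, `CC[C@H](C)[C@H](NC(=O)OC(C)(C)C)C(=O)N(Cc1ccccc1)C1(C(=O)NCc2ccccc2)CCN(Cc2ccccc2)CC1`, differs from it in one place: sec-butyl in place of (methoxycarbonyl)methyl on a saturated chain carbon bound to an amide-type nitrogen and a carbonyl carbon. Among the compounds with values here, the step of a 4.1-fold lower number from compound 1 to compound 2 (0.61 log units; beyond the scatter) is the only measured instance of this change, and in this assay compound 2 gives 4400 nM.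

Compound 3, `CCC(C)N(C(=O)[C@H](CC(=O)OC)NC(=O)OCc1ccccc1)C1(C(=O)NCc2ccccc2)CCN(Cc2ccccc2)CC1`, has the same atoms as compound 1 joined differently; the difference between the two cores is not broken down here. In this assay compound 3 gives 5300 nM, which lies within the scatter of compound 2 and beyond it relative to compound 1.

Compound 4, `CCC(C)N(C(=O)[C@@H](NC(=O)OCc1ccccc1)[C@@H](C)CC)C1(C(=O)NCc2ccccc2)CCN(Cc2ccccc2)CC1`, has not yet been measured. It stands to compound 3 as compound 2 stands to compound 1: sec-butyl in place of (methoxycarbonyl)methyl on a saturated chain carbon bound to an amide-type nitrogen and a carbonyl carbon. The place is the same word for word, so this is the same change made a second time, now on the core of compound 3.

The expectation rests on one example only. Because the step of a 4.1-fold lower number from compound 1 to compound 2 (0.61 log units; beyond the scatter) was modest but beyond the scatter, compound 4 is expected to show a similar lowering, a 3.5-fold lower number from compound 3 to compound 4 (0.55 log units; beyond the scatter), though with a single precedent on a different core the size is uncertain. Compound 4 is therefore estimated at 1500 nM in this assay, with a likely range from 600 nM to 4000 nM.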

Compound 4, half-maximal inhibitory concentration: 83000 nM
Compound 4: middle estimate off by 55-fold (1.74 log units), on the low side, outside the stated range (above it).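

The same replacement of (methoxycarbonyl)methyl by sec-butyl, on a saturated chain carbon bound to an amide-type nitrogen and a carbonyl carbon, went the other way on the second core in this assay, giving a 16-fold higher number from compound 3 to compound 4 (1.19 log units; beyond the scatter). Set side by side, the two instances disagree in direction as well as in size: the same change on two cores in this assay, a 4.1-fold lower number (0.61 log units; beyond the scatter) from compound 1 to compound 2 and a 16-fold higher number (1.19 log units; beyond the scatter) from compound 3 to compound 4, 64-fold (1.81 log units) apart, beyond the scatter of two such steps. This shows that, for these two pairs, the result of the change on the core of compound 1 does not carry over to the core of compound 3, but it does not show which feature of the two cores decides the outcome, and two pairs give no general rule for the series.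

The compounds shown leave open how other groups at this place would behave on each core, for example a carboxylic acid or an isobutyl chain in place of (methoxycarbonyl)methyl. They also leave open which of the structural differences between the two cores reverses the step, a question that would need compounds differing from one another in only one of those features.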